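Swapping the aryl amide arm: expected cytotoxicity of compound 4

A few compounds are considered here, and "the series" means these few. Any claim that something is new, unique, unknown or untested is made for them only; others in the source may bear on it.

Measured compounds:
- compound 1 `O=C(NO)c1ccc(N(Cc2ccc(C3CCOCC3)cc2)C(=O)[C@H]2CCN2S(=O)(=O)c2c(F)c(F)c(F)c(F)c2F)cc1`: 4300 nM
- compound 2 `CONC(=O)c1ccc(N(Cc2ccc(C3CCCCC3)cn2)C(=O)[C@H]2CCN2S(=O)(=O)c2c(F)c(F)c(F)c(F)c2F)cc1O`: "not determined" (no result reported)
- compound 3 `O=C(NO)c1ccc(N(Cc2ccc(C3CCCC3)cn2)C(=O)[C@H]2CCN2S(=O)(=O)c2c(F)c(F)c(F)c(F)c2F)c(F)c1`: "not determined" (no result reported)

In an ADME assay on MCF-10A cells (Homo sapiens) for cytotoxicity, with a stated time of 72 h (on this read-out higher numbers stand for an effect only at larger amounts of compound and lower numbers for an effect already at smaller amounts), compound 1 gives 4300 nM. In this assay compound 2 gives "not determined" (no result reported), and compound 3 gives "not determined" (no result reported), so only compound 1 supplies a measured anchor for the series.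

Compound 4 `O=C([C@H]1CCN1S(=O)(=O)c1c(F)c(F)c(F)c(F)c1F)N(Cc1ccc(C2CCCCC2)cn1)c1ccc2c(=O)[nH]ccc2c1` is still to be measured. It differs from compound 2 in one place: a group of 11 heavy atoms (9 carbon, 1 nitrogen, 1 oxygen; one six-membered aromatic ring of carbon only, one six-membered aromatic ring with 1 hetero atom) in place of a group of 12 heavy atoms (8 carbon, 1 nitrogen, 3 oxygen; one six-membered aromatic ring of carbon only), on an amide-type nitrogen. Going by the values given here, no step between two measured compounds is available to calibrate this change. Given that compound 2 itself has no number, the expectation for compound 4 can rest only on the value of compound 1 in this assay. A step from compound 2 to compound 4 of at most modest size is expected, leaning toward higher numbers in this assay rather than lower, but it could well be none beyond the usual scatter.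

On that basis compound 4 is estimated at 9000 nM in this assay, with a plausible range from 3000 nM to 30000 nM.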

Compound 4, half-maximal effective concentration: 2700 nM
The estimate for compound 4 lay 3.3-fold (0.52 log units) above the measured number; the whole stated range lies above it.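

Going by these compounds alone, compound 2 has no single number in this assay, so no step to compound 4, at 2700 nM, can be read from this result. The compounds shown leave open whether replacing the 3-hydroxy-4-(methoxycarbamoyl)phenyl group on the amide-type nitrogen changes the read-out at all. Nothing at hand speaks to an explanation for the value of compound 4.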